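Acetamido in Place of Cyano on a Receptor Antagonist

The compounds below may be only part of what the source reports. "The series", "measured", "known", "first", "only" and "open" are said of these compounds alone.

Compound 1 `Cc1cc(COc2cccc(C#N)c2)nc(-c2ccccn2)n1` and compound 2 `Cc1cc(COc2ccc(C#N)cc2)nc(-c2ccccn2)n1` are built from the same atoms joined differently; the difference between the two cores is not broken down here. In a functional assay on cells for antagonist activity at Free fatty acid receptor 1 (Homo sapiens), read by TR-FRET and inositol phosphate accumulation, with a stated time of 2 h (a higher number here means a weaker inhibitor, a lower number a stronger inhibitor), compound 1 gives 2510 nM, while compound 2 gives 31600 nM. Compound 3 `CC(=O)Nc1cccc(OCc2cc(C)nc(-c3ccccn3)n2)c1` carries an acetamido in place of the cyano of compound 1, the group sitting meta to a large group (acetamido in place of cyano on an aromatic carbon). For compound 3 the result in this assay is a limit of the assay, > 39800 nM, not a number. The change gave an at least 15-fold higher number from compound 1 to compound 3 (1.20 log units; beyond the scatter), reaching (the limit of > 39800 nM in this assay, at which 1 of the 3 values shown sits).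

Compound 4 `CC(=O)Nc1ccc(OCc2cc(C)nc(-c3ccccn3)n2)cc1` is not yet measured. It carries the same kind of change relative to compound 2, here with the group para to a large group (acetamido in place of cyano on an aromatic carbon). Compound 2 already starts at a high number, and the earlier change of this kind pushed the result to the limit. The expected step in this assay is therefore a 1.9-fold higher number from compound 2 to compound 4 (0.28 log units; within the scatter), most likely again ending at the limit. For compound 4 the estimate in this assay is 60000 nM, expected to lie between 15000 nM and 250000 nM.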

Compound 4, half-maximal inhibitory concentration: > 39800 nM
Compound 4: no number, only a limit; the forecaster's own chance of this, stated with the estimate: 85%; the middle value does not contradict the limit.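

Acetamido in place of cyano leaves compound 4 at > 39800 nM in this assay, which is a limit of the assay and not a number. The step is an at least 1.2-fold higher number from compound 2 to compound 4 (0.10 log units; that floor lies within the scatter), so only a floor is known on this core and the true size of the step stays hidden. The change ends at the limit on both cores, but that does not show that it has the same size on each: the same change on two cores in this assay, an at least 15-fold higher number (1.20 log units; beyond the scatter) from compound 1 to compound 3 and an at least 1.2-fold higher number (0.10 log units; that floor lies within the scatter) from compound 2 to compound 4; the limit leaves it open whether they differ

The compounds shown leave open what other groups would do in the place of the cyano on these two cores, for example an amine, a carboxylic acid, or a longer chain on the amide carbonyl. A group that gave a real number rather than a limit on both cores would allow the two steps to be compared directly.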